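Furan for Benzofuran on Two Nucleoside Cores

The compounds below may be only part of what the source reports. "The series", "measured", "known", "first", "only" and "open" are said of these compounds alone.

Compound 2 `Cc1nc(N)c2c(-c3cc4ccccc4o3)cn([C@@H]3O[C@H](CO)[C@@H](O)[C@H]3O)c2n1` carries a 1-benzofuran-2-yl group on its core. In a functional assay on HepG2 cells (Homo sapiens) for antiproliferative activity, read by XTT assay, with a stated time of 72 h (a lower number here means a stronger inhibitor, a higher number a weaker inhibitor), compound 2 gives > 20000 nM, which is a limit of the assay rather than a number. Compound 1 `Cc1nc(N)c2c(-c3ccco3)cn([C@@H]3O[C@H](CO)[C@@H](O)[C@H]3O)c2n1` differs from it by furan-2-yl in place of 1-benzofuran-2-yl on an aromatic carbon. Compound 1 gives > 20000 nM, again a limit. The step that the two limits leave unreadable from compound 2 to compound 1 therefore has no readable size. Compound 3 `CNc1ncnc2c1c(-c1cc3ccccc3o1)cn2[C@@H]1O[C@H](CO)[C@@H](O)[C@H]1O` has the same atoms as compound 2 joined differently; the difference between the two cores is not broken down here. Compound 3 gives > 20000 nM, also a limit. Compound 4 `CNc1ncnc2c1c(-c1ccco1)cn2[C@@H]1O[C@H](CO)[C@@H](O)[C@H]1O` is not yet measured and differs from compound 3 by furan-2-yl in place of 1-benzofuran-2-yl on an aromatic carbon, the same change as from compound 2 to compound 1. For the measured compounds named here, because of the limit of > 20000 nM in this assay, at which 3 of the 3 values shown sit, no measured step can be sized. The step that the limit leaves unreadable from compound 3 to compound 4 is expected to remain unreadable in the same way. Compound 4 is estimated at 30000 nM, most likely reported once more as a limit, within a range from 20000 nM to 100000 nM.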

Compound 4, half-maximal inhibitory concentration: 850 nM
For compound 4 the middle estimate is 35-fold (1.55 log units) above the measured one, outside the stated range (below it).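

In this assay, furan-2-yl in place of 1-benzofuran-2-yl gives an at least 23-fold lower number from compound 3 to compound 4 (1.37 log units; beyond the scatter), so on this core the change has a large effect. Compound 1 gives > 20000 nM, which is a limit of the assay, so the same change on the core of compound 2 does not yield a measurable number. This shows that a large effect on one core did not bring the other core's furan-2-yl compound into the measurable range, but it does not show how far the change moved that compound, and the steps that end at limits cannot be read, because most values sit at the same limit: the limit of > 20000 nM in this assay, at which 3 of the 4 values shown sit.

As far as these compounds go, how a thiophen-2-yl or phenyl group at this place would read on either core remains open. Also open, from the compounds shown here alone, is which feature of the two cores decides the outcome.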